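The compounds below may be only part of what the source reports. "The series", "measured", "known", "first", "only" and "open" are said of these compounds alone.

Compound 2 `COc1cc(CC(O)c2ccc(-c3ccc(Br)cc3)cc2)c([N+](=O)[O-])cc1OC` gives 4300 nM in an ADME assay on HeLa Rh cells (Homo sapiens) for cytotoxicity, read by microscopy (on this read-out higher numbers stand for lower toxicity in this test and lower numbers for higher toxicity in this test), and holds the lowest of the two numbers recorded there. Compound 3 `COc1cc(CC(O)c2ccc(-c3ccccc3C#N)cc2)c([N+](=O)[O-])cc1OC` gives 9300 nM, so the step of a 2.2-fold higher number from compound 2 to compound 3 (0.34 log units; beyond the scatter) is modest. Compound 1 `COc1cc(CC(O)c2ccc(-c3ccc(CO)cc3)cc2)c([N+](=O)[O-])cc1OC` gives > 244000 nM, which is a limit of the assay rather than a number (the limit of > 244000 nM in this assay, at which 1 of the 3 values shown sits). Measured from it, the steps of an at least 56-fold lower number from compound 1 to compound 2 (1.75 log units; beyond the scatter) and an at least 26-fold lower number from compound 1 to compound 3 (1.41 log units; beyond the scatter) are both large. Compound 4 `COc1cc(CC(O)c2ccc(-c3cccnc3)cc2)c([N+](=O)[O-])cc1OC` carries pyridin-3-yl in place of 4-bromophenyl on an aromatic carbon. This change sits at the same place as the change between compound 2 and compound 3, so that modest step bears most on it, while the large steps from compound 1 show how far a change here can reach. For compound 4 a moderate rise is expected, estimated at 12000 nM with a range of 4000 nM to 40000 nM, meaning an expected step of a 2.8-fold higher number from compound 2 to compound 4 (0.45 log units; beyond the scatter).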

Compound 4, half-maximal cytotoxic concentration: > 263000 nM
Compound 4 ended at the assay's limit; the forecaster's own chance of this, stated with the estimate: 10%; middle value at least 21-fold (1.34 log units) from the limit.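

Pyridin-3-yl in place of 4-bromophenyl gives an at least 61-fold higher number from compound 2 to compound 4 (1.78 log units; beyond the scatter), and in place of 2-cyanophenyl it gives an at least 28-fold higher number from compound 3 to compound 4 (1.45 log units; beyond the scatter). A large rise at this place therefore does not depend on the hydroxymethyl group of compound 1, since an unsubstituted ring with one hetero atom also produces it. The value of compound 4 is a limit of the assay, not a number: the limit of > 263000 nM in this assay, at which 1 of the 4 values shown sits.

The step between compound 1 and compound 4 cannot be read, as both values are limits. Going by these compounds, whether an amine or a carboxylic acid on the ring at this place would behave likewise stays open.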